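A few compounds are considered here, and "the series" means these few. Any claim that something is new, unique, unknown or untested is made for them only; others in the source may bear on it.

Of the compounds shown here, two from this series have been tested in a functional assay on CCRF-CEM cells (Homo sapiens) for cytotoxicity, read by sulforhodamine B assay, with a stated time of 48 h; on this read-out lower numbers stand for stronger inhibition of growth and higher numbers for weaker inhibition of growth. Among the measured compounds shown here, compound 2, with the structure `ClCc1ccccc1Cn1cnc2c(Cl)nc(Cl)nc21`, is the only one that gives a number: in this assay compound 2 reaches 90 nM. Compound 1, with the structure `ClCc1ccc(Cn2cnc3c(Cl)ncnc32)cc1`, stands apart, since in this assay compound 1 returns only a limit of the assay, > 100000 nM; this is the limit of > 100000 nM in this assay, at which 1 of the 2 values shown sits, and it is not a measured number. For the measured compounds named here, compound 1 and compound 2 differ in more than one place, so their two values show only that one compound is active and the other is not within the range of the test.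

The next compound, compound 3, has the structure `ClCc1ccccc1Cn1cnc2c(Cl)ncnc21`. Compared with compound 2, the change is hydrogen in place of chloro on an aromatic carbon between two ring nitrogen atoms. Going by the values given here, no measured pair isolates this change, so the expectation rests on compound 2 alone. Removing one chloro is expected to weaken the growth inhibition, with the step from compound 2 to compound 3 estimated at an 11-fold higher number from compound 2 to compound 3 (1.05 log units; beyond the scatter). Compound 3 is therefore expected to give about 1000 nM, somewhere between 150 nM and 20000 nM.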

Compound 3, concentration for total growth inhibition: 3230 nM
Compound 3: the middle estimate sits 3.2-fold (0.51 log units) below what was measured; low and high end bracket the measured number.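

Among the compounds shown here, this is the first pair that differs in one place only, so the chloro on the aromatic carbon between two ring nitrogen atoms can now be judged on its own. In this assay, putting hydrogen in its place gives a 36-fold higher number from compound 2 to compound 3 (1.55 log units; beyond the scatter), a large change that shows growth inhibition in this pair depends strongly on this one atom. Even so, the chloro is not essential for a readable result, since compound 3 still gives a measured number, 3230 nM, rather than a limit of the assay, although nothing shown here explains why this position matters so much.

This is a single pair, so it cannot show whether the same change would have a similar effect in a compound with the chloromethyl group placed as in compound 1. The compounds shown also leave open where other groups on this carbon would fall relative to chloro and hydrogen, such as an amine, a methyl group or a bromo group, and whether any of them would match or pass compound 2.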